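The source may report more compounds than this note shows. Statements on the series, on what has been measured and on what is new or still open speak of the compounds shown alone.

Among the measured compounds shown here, in a functional assay on A549 cells (Homo sapiens) for cytotoxicity, with a stated time of 48 h (on this read-out higher numbers stand for weaker inhibition and lower numbers for stronger inhibition), compound 1 `CC(C)C(=O)Oc1ccc2oc(/C=C/[S+](C)[O-])cc(=O)c2c1` gives 2400 nM, the highest of the three numbers known so far. Compound 2 `CC(C)Oc1ccc2oc(/C=C/[S+](C)[O-])cc(=O)c2c1` gives 1500 nM, and compound 3 `C[S+]([O-])/C=C/c1cc(=O)c2cc(Br)ccc2o1` gives 1100 nM. The step of a 1.6-fold lower number from compound 1 to compound 2 (0.20 log units; within the scatter) and the step of a 1.4-fold lower number from compound 2 to compound 3 (0.13 log units; within the scatter) are both small, while the step of a 2.2-fold lower number from compound 1 to compound 3 (0.34 log units; beyond the scatter) is modest. Compound 4 `C[S+]([O-])/C=C/c1cc(=O)c2cc(O)ccc2o1` has not yet been measured in this assay; it differs from compound 1 by hydrogen in place of isopropylcarbonyl on an oxygen on an aromatic ring. The measured step that bears most on this is a 1.6-fold lower number from compound 1 to compound 2 (0.20 log units; within the scatter), where the isopropylcarbonyl was likewise removed from the oxygen on the aromatic ring, though there an isopropyl took its place; that step stayed within the scatter. For the measured compounds named here, no measured step cuts the group on that oxygen down to hydrogen, so the comparison is indirect. A change no larger than the scatter is therefore expected for compound 4, a 1.5-fold lower number from compound 1 to compound 4 (0.18 log units; within the scatter), with no firm direction. Compound 4 is estimated at 1600 nM, within a range from 600 nM to 4500 nM.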

Compound 4, half-maximal inhibitory concentration: 10500 nM
Compound 4: middle estimate off by 6.6-fold (0.82 log units), on the low side, and the stated range ends below it.
By their numbers in this assay, from the lowest: compounds 3, 2 and 1 (each within the scatter of the next, the first and the last beyond it); then compound 4.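

In this assay, a bare hydroxy at this position gives weaker inhibition than any other group shown, a change the earlier compounds gave no sign of. Removing the isopropylcarbonyl from the oxygen gives a 4.4-fold higher number from compound 1 to compound 4 (0.64 log units; beyond the scatter), and removing the isopropyl gives a 7.0-fold higher number from compound 2 to compound 4 (0.85 log units; beyond the scatter), both beyond the scatter, whereas swapping one of these groups for the other had stayed within it. Hydroxy in place of bromo on the aromatic carbon gives the largest step, a 9.5-fold higher number from compound 3 to compound 4 (0.98 log units; beyond the scatter), so all three groups on this carbon give lower numbers than hydroxy.

No evidence is available on what lies behind this gap. The compounds shown leave open whether an amine, a carboxylic acid or a longer chain on that aromatic carbon would give a number nearer compound 4 or the other three.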